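The source may report more compounds than this note shows. Statements on the series, on what has been measured and on what is new or still open speak of the compounds shown alone.

Two ureas on the shared core have been run through a functional assay on SK-HEP1 cells (Homo sapiens) for antiproliferative activity, read by sulforhodamine B assay; on this read-out lower numbers stand for stronger inhibition of growth and higher numbers for weaker inhibition of growth. In this assay compound 1 `COc1ccccc1NC(=O)Nc1nc2ccc(F)cc2s1` gives > 10 ug/mL, which is a limit of the assay and not a number. Compound 2 `COc1ccc(NC(=O)Nc2nc3ccc(F)cc3s2)cc1` likewise returns > 10 ug/mL in this assay, again a limit rather than a number. Where compound 2 stands is therefore set only by the limit of > 10 ug/mL in this assay, at which 2 of the 2 values shown sit. For the measured compounds named here, no measured step between two compounds exists in this set, so nothing shows how any single change moves the growth inhibition.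

Compound 3 `O=C(Nc1ccccc1)Nc1nc2ccc(F)cc2s1` is the next compound for this assay. It differs from compound 2 by hydrogen in place of methoxy on an aromatic carbon. With both measured values sitting at the limit, the size of the step in this assay cannot be read from any comparison. The working expectation is a step of no more than the scatter, with another limit the most likely report. The estimate for compound 3 is therefore 15 ug/mL, within 5 ug/mL to 45 ug/mL. The expected step is a step that the limit leaves unreadable from compound 2 to compound 3, an estimate and not a measurement.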

Compound 3, concentration for 50% growth inhibition: > 10 ug/mL
Compound 3: a limit, no number; the forecaster's own chance of this, stated with the estimate: 70%; the middle value lies beyond the limit too.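

In this assay compound 3 gives > 10 ug/mL, a limit of the assay and not a number. No step from compound 1 or compound 2 to compound 3 can be read, because the result adds only another limit: the limit of > 10 ug/mL in this assay, at which 3 of the 3 values shown sit.

The compounds shown leave open whether any urea on the shared core reaches a readable growth inhibition.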